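The source may report more compounds than this note shows. Statements on the series, on what has been measured and on what is new or still open speak of the compounds shown alone.

Three compounds of the series are in hand: compound 1 `[O-][S+](CCC(F)=C(F)F)c1nc2ccccc2s1`, compound 2 `O=S(=O)(CCC(F)=C(F)F)c1nc2ccc(OC(F)F)cc2[nH]1` and compound 3 `[O-][S+](CCC(F)=C(F)F)c1nccs1`. In a functional assay on SH-SY5Y cells (Homo sapiens) for cytotoxicity, read by MTT assay, with a stated time of 48 h (a lower number here means a stronger inhibitor, a higher number a weaker inhibitor), compound 1 gives 7000 nM. For compound 2 this assay reports only a limit, > 120000 nM. Compound 3 likewise returns only a limit, > 120000 nM. Compound 2 thus stands at the weak end of the numbers shown, sitting at the limit of > 120000 nM in this assay, at which 2 of the 3 values shown sit. Compound 4 `O=S(=O)(CCC(F)=C(F)F)c1nc2ccccc2[nH]1` is not yet measured; it differs from compound 2 by hydrogen in place of difluoromethoxy on an aromatic carbon. Among the measured compounds shown here, no measured pair in the set differs in a single place, so no step size can be read off; the expectation is a change not beyond the usual scatter, and the step is estimated as a number no higher from compound 2 to compound 4 (the limit leaves the size open). Compound 4 is expected near 120000 nM, between 40000 nM and 400000 nM, with a limit again the likely outcome.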

Compound 4, half-maximal inhibitory concentration: > 120000 nM
Compound 4 was reported as a limit; the forecaster's own chance of this, stated with the estimate: 70%; the middle value lies on the limit itself.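

Compound 2 and compound 4 both return only limits, and the step between them, hydrogen in place of difluoromethoxy on an aromatic carbon, cannot be read. The compounds shown leave open whether this exchange changes the read-out at all.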